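A Tail Change Tested Against a Measured Cytotoxicity Baseline

The compounds below may be only part of what the source reports. "The series", "measured", "known", "first", "only" and "open" are said of these compounds alone.

Among the measured compounds shown here, compound 1 `COc1cc2c(Oc3ccc(NC(=O)c4nccc(-c5ccc(F)cc5)n4)cc3F)ccnc2cc1OCCCN1CCN(C)CC1` stands lowest of the two numbers so far in a functional assay on NCI-H460 cells (Homo sapiens) for cytotoxicity, read by MTT assay, with a stated time of 72 h (on this read-out lower numbers stand for stronger inhibition and higher numbers for weaker inhibition), where compound 1 gives 63 nM. For the measured compounds named here, its only measured neighbour is compound 2 `COc1cc2c(Oc3ccc(NC(=O)c4nccc(-c5ccc(F)cc5F)n4)cc3F)ccnc2cc1OCCCN1CCN(C)CC1`, which in this assay gives 450 nM; that step, a 7.1-fold higher number from compound 1 to compound 2 (0.85 log units; beyond the scatter), comes from fluoro in place of hydrogen on an aromatic carbon. Compound 3 `COc1cc2c(Oc3ccc(NC(=O)c4nccc(-c5ccc(F)cc5)n4)cc3F)ccnc2cc1OCCCN1CCCC1` differs from compound 1 in a different place: pyrrolidin-1-yl in place of 4-methylpiperazin-1-yl on a saturated chain carbon, three bonds along the chain from an oxygen on an aromatic ring. Going by the values given here, none of the measured steps touches this chain end, so the step from compound 1 to compound 2 does not bear on the change, and there is no basis in the numbers for expecting a shift beyond the scatter in this assay in either direction. Compound 3 is therefore expected to give 80 nM, within a range of 25 nM to 250 nM. That estimated step, a 1.3-fold higher number from compound 1 to compound 3 (0.10 log units; within the scatter), is expected to stay within the scatter.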

Compound 3, half-maximal inhibitory concentration: 300 nM
Beside the measured number, compound 3's estimate is 3.8-fold (0.57 log units) below it; the whole stated range lies below it.
By their numbers in this assay, from the lowest: compound 1; then compounds 3 and 2 (each within the scatter of the next).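

In this assay the chain end proves not to be a silent place: pyrrolidin-1-yl in place of 4-methylpiperazin-1-yl gives a 4.8-fold higher number from compound 1 to compound 3 (0.68 log units; beyond the scatter). Compound 1 now has measured neighbours at two separate places, the fluoro step being a 7.1-fold higher number from compound 1 to compound 2 (0.85 log units; beyond the scatter), and each change leaves the neighbour with a higher number than compound 1. No independent measurement accompanies these numbers to say why the chain-end change shifts the result.

The compounds shown do not separate the size of the ring from the loss of the second ring nitrogen and its methyl group; a piperidin-1-yl or a morpholin-4-yl group at the same chain end would speak to that. Also open, going by these compounds, is whether the chain-end step would keep its size on compound 2.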